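The source may report more compounds than this note shows. Statements on the series, on what has been measured and on what is new or still open speak of the compounds shown alone.

In a functional assay on CCRF-CEM cells (Homo sapiens) for inhibition, read by cell counting, with a stated time of 3 days (on this read-out higher numbers stand for weaker inhibition and lower numbers for stronger inhibition), compound 1 `C=C(Br)C(=O)Nc1cccc(-c2cn3nc(-c4ccc(OCC)cc4)sc3n2)c1` gives 1400 nM, the lowest of the three numbers in hand. Compound 2 `Nc1cccc(-c2cn3nc(Cc4ccc(Cl)cc4)sc3n2)c1` gives 42000 nM and compound 3 `Nc1cccc(-c2cn3nc(Cc4ccccc4)sc3n2)c1` gives 37000 nM; both carry a free amine where compound 1 carries the bromoacrylamide, and both stand beyond the scatter from compound 1. Within the data shown here, the only step between measured compounds, a 1.1-fold lower number from compound 2 to compound 3 (0.06 log units; within the scatter), concerns a different part of the series, a chloro on an aromatic carbon, and stays within the scatter.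

Compound 4 `C=C(Br)C(=O)Nc1cccc(-c2cn3nc(-c4cccs4)sc3n2)c1` keeps the bromoacrylamide of compound 1 and changes the group on an aromatic carbon of the shared core: thiophen-2-yl in place of 4-ethoxyphenyl on an aromatic carbon. Among the measured compounds shown here, no measured pair varies this position with the acrylamide held constant, so the step from compound 2 to compound 3 offers only a loose hint that a change of aryl group away from the acrylamide produces little movement. Compound 4 is therefore expected to give about 2000 nM, within 500 nM to 8000 nM. The expected step is a 1.4-fold higher number from compound 1 to compound 4 (0.15 log units; within the scatter), not clearly beyond the scatter in either direction.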

Compound 4, half-maximal inhibitory concentration: 410 nM
Compound 4: the middle estimate sits 4.9-fold (0.69 log units) above what was measured; the measured number lies below the stated range.
By their numbers in this assay, from the lowest: compound 4; then compound 1; then compounds 3 and 2 (each within the scatter of the next).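

In this assay, among these compounds, thiophen-2-yl in place of 4-ethoxyphenyl gives a 3.4-fold lower number from compound 1 to compound 4 (0.53 log units; beyond the scatter), the first change at this position with the bromoacrylamide held constant. The group on this aromatic carbon therefore does move the number, unlike the chloro step in the free-amine pair, although that step lies in a different part of the series. The larger 4-ethoxyphenyl is also not required for activity in this range, since the smaller thiophen-2-yl gives the lower number, and no measurement in hand accounts for this step.

A single pair cannot separate the change of ring from the loss of the ethoxy group, which unsubstituted phenyl at this position would help to resolve. Going by these compounds, the contribution of the bromoacrylamide also stays open, and a free amine paired with thiophen-2-yl would isolate it.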